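The source may report more compounds than this note shows. Statements on the series, on what has been measured and on what is new or still open speak of the compounds shown alone.

In a functional assay on HepG2 cells (Homo sapiens) for inhibition, read by MTT assay, with a stated time of 72 h (a lower number here means a stronger inhibitor, a higher number a weaker inhibitor), three related compounds have been measured so far. Compound 1 `Cc1ccc(-c2nnc(SCCCN3CCN(c4nc5ccccc5o4)CC3)o2)cc1` gives 154000 nM, compound 2 `Oc1ccc(-c2nnc(SCCCN3CCN(c4nc5ccccc5o4)CC3)o2)cc1` gives 502000 nM, and compound 3 `Cc1ccc(-c2nnc(SCCCN3CCN(c4nc5ccccc5s4)CC3)o2)cc1` gives 96700 nM. Compound 3 has the lowest of these numbers, but the comparison with its nearest neighbour shows a 1.6-fold lower number from compound 1 to compound 3 (0.20 log units; within the scatter), so those two stand level. Its number is clearly lower than that of compound 2.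

The next compound, compound 4 `Oc1ccc(-c2nnc(SCCCN3CCN(c4nc5ccccc5s4)CC3)o2)cc1`, differs from compound 3 in a single group: hydroxy in place of methyl on an aromatic carbon. In other words, 4-methylphenyl becomes 4-hydroxyphenyl. The same swap has been measured once, in the pair carrying 1,3-benzoxazol-2-yl instead of 1,3-benzothiazol-2-yl, and it gave a 3.3-fold higher number from compound 1 to compound 2 (0.51 log units; beyond the scatter). For the measured compounds named here, that one step is the only direct guide, and a single pair proves no rule. A modest step of similar size towards a higher number, meaning a weaker inhibitor, is therefore expected in this assay. The expected change is a 3.3-fold higher number from compound 3 to compound 4 (0.51 log units; beyond the scatter). The estimate for compound 4 is 315000 nM, with an expected range from 150000 nM to 650000 nM.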

Compound 4, half-maximal inhibitory concentration: 364000 nM
Beside the measured number, compound 4's estimate is 1.2-fold (0.06 log units) below it, within the range that was stated.
By their numbers in this assay, from the lowest: compounds 3 and 1 (each within the scatter of the next); then compounds 4 and 2 (each within the scatter of the next).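

In this assay, replacing 4-methylphenyl with 4-hydroxyphenyl gives a 3.8-fold higher number from compound 3 to compound 4 (0.58 log units; beyond the scatter), so the rise no longer rests on a single pair and now holds on a second core: the same change on two cores in this assay, a 3.3-fold higher number (0.51 log units; beyond the scatter) from compound 1 to compound 2 and a 3.8-fold higher number (0.58 log units; beyond the scatter) from compound 3 to compound 4, 1.2-fold (0.06 log units) apart, within the scatter of two such steps. The other change, 1,3-benzothiazol-2-yl in place of 1,3-benzoxazol-2-yl, gives a 1.4-fold lower number from compound 2 to compound 4 (0.14 log units; within the scatter), which means that it stays within the scatter with either methyl or hydroxy on the aromatic ring: the same change on two cores in this assay, a 1.6-fold lower number (0.20 log units; within the scatter) from compound 1 to compound 3 and a 1.4-fold lower number (0.14 log units; within the scatter) from compound 2 to compound 4, 1.2-fold (0.06 log units) apart, within the scatter of two such steps. Across these four compounds, only the change from methyl to hydroxy moves the number beyond the scatter, and no compound goes against this.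

The compounds shown carry only methyl or hydroxy at this place, so it remains open how a methoxy group, an amine or a fluorine there would compare. Going by these compounds, what a longer chain joining the two halves of the molecule would do also remains open.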